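The source may hold more compounds than are shown below. What is called first, only, known or untested is meant among the compounds shown, and "the series" means these compounds.

Series on the shared core `COC1=C(C)C(=O)/C(=C(O)/C=C/c2ccc(Br)cc2)C(=O)C1(C)C` of compound 1. In a functional assay on HUVEC cells (Homo sapiens) (a lower number here means that less compound is needed, a higher number that more compound is needed for the effect), compound 1 gives < 4 ug/mL, which is a limit of the assay and not a number. Compound 2 `COC1=C(C)C(=O)/C(=C(O)/C=C/c2ccc(OC)cc2)C(=O)C1(C)C` likewise gives < 4 ug/mL, also a limit. Compound 3 `COC1=C(C)C(=O)/C(=C(O)/C=C/c2ccc(C)cc2)C(=O)C1(C)C` gives < 4 ug/mL, again a limit. The steps a step that the two limits leave unreadable from compound 1 to compound 2, a step that the two limits leave unreadable from compound 1 to compound 3 and a step that the two limits leave unreadable from compound 2 to compound 3 stay unreadable because of the limit of < 4 ug/mL in this assay, at which 3 of the 3 values shown sit. Compound 4 `COC1=C(C)C(=O)/C(=C(O)/C=C/c2cccs2)C(=O)C1(C)C` differs from compound 1 by thiophen-2-yl in place of 4-bromophenyl on a double-bonded chain carbon bound to a double-bonded chain carbon. For the measured compounds named here, no measured step exchanges the ring itself, so none bears directly on this change, and the substituent swaps on the aromatic carbon give no readable size. The expected step that the limit leaves unreadable from compound 1 to compound 4 is therefore small, with no direction beyond the scatter. Compound 4 is estimated at 2.5 ug/mL, with a range from 0.6 ug/mL to 10 ug/mL.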

Compound 4, concentration for half-maximal effect: < 4 ug/mL
Compound 4 was reported as a limit; the forecaster's own chance of this, stated with the estimate: 65%; the middle value lies beyond the limit too.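

No step can be read from compound 4 to compound 1, compound 2 or compound 3, because the result is again a limit: the limit of < 4 ug/mL in this assay, at which 4 of the 4 values shown sit.

The compounds shown leave open whether thiophen-2-yl and the 4-bromophenyl, 4-methoxyphenyl and 4-methylphenyl groups differ at all in this assay.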